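The source may report more compounds than this note shows. Statements on the series, on what has been measured and on what is new or still open speak of the compounds shown alone.

In a functional assay on the whole organism with Mus musculus as the target, in the maximal electroshock model (on this read-out lower numbers stand for an effect already at smaller amounts and higher numbers for an effect only at larger amounts of compound), compound 2 (`O=C1CCC(Cc2ccc(Cl)cc2)C(=O)N1`) gives 137 mg/kg and compound 1 (`CN1C(=O)CCC(Cc2ccc(Br)cc2)C1=O`) gives 162 mg/kg, two values within the scatter of each other. Compound 3 (`CN1C(=O)CCC(Cc2ccc(Cl)cc2)C1=O`) differs from compound 2 by methyl in place of hydrogen on an amide-type nitrogen in a ring. Among the measured compounds shown here, the series offers no measured step to go by, so no shift beyond the scatter is expected in this assay, in either direction. The estimated change is a 1.1-fold higher number from compound 2 to compound 3 (0.04 log units; within the scatter). Compound 3 is expected at 150 mg/kg, with an estimated range of 75 mg/kg to 300 mg/kg.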

Compound 3, dose for half-maximal effect: 248 mg/kg
Estimate against measurement, compound 3: 1.7-fold (0.22 log units) below, within the range that was stated.
By their numbers in this assay, from the lowest: compounds 2, 1 and 3 (each within the scatter of the next).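

Methyl in place of hydrogen on an amide-type nitrogen in a ring gives the first read at this position in this assay (a 1.8-fold higher number from compound 2 to compound 3 (0.26 log units; within the scatter)), and the step stays within the scatter. With the methyl on that nitrogen in both compounds, chloro in place of bromo on an aromatic carbon also stays within the scatter (a 1.5-fold higher number from compound 1 to compound 3 (0.18 log units; within the scatter)). No measured evidence bears on either step.

Open, from the compounds shown here alone, is whether an ethyl group or a longer chain ending in an amine on that nitrogen would give a step beyond the scatter. Also open, going by these compounds, is what fluoro or methoxy would do on the aromatic carbon.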